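Amide-nitrogen variation in a HeLa cytotoxicity series

The source may hold more compounds than are shown below. What is called first, only, known or untested is meant among the compounds shown, and "the series" means these compounds.

compound 1 `NNC(=O)Cn1nc(N)c2c(C(F)(F)F)cc(-c3ccccc3)nc21` — 48400 nM
compound 2 `Nc1nn(CC(=O)NCc2ccccc2)c2nc(-c3ccccc3)cc(C(F)(F)F)c12` — 17100 nM

In a functional assay on HeLa cells (Homo sapiens) for cytotoxicity, read by MTT assay, with a stated time of 24 h (on this read-out lower numbers stand for stronger inhibition and higher numbers for weaker inhibition), compound 1 gives 48400 nM, the highest of the two numbers; compound 2 gives 17100 nM, and the step of a 2.8-fold lower number from compound 1 to compound 2 (0.45 log units; beyond the scatter) is the only one in hand. Compound 3 `CC(NC(=O)Cn1nc(N)c2c(C(F)(F)F)cc(-c3ccccc3)nc21)C(=O)O` is still to be measured and differs from compound 1 by 1-carboxyethyl in place of amino on an amide-type nitrogen. That step bears on it only loosely, since 1-carboxyethyl is not benzyl, so a step no larger than a 2.8-fold lower number from compound 1 to compound 2 (0.45 log units; beyond the scatter) is expected, and possibly none beyond the scatter. Compound 3 is expected at 40000 nM, range 15000 nM to 110000 nM, a step of a 1.2-fold lower number from compound 1 to compound 3 (0.08 log units; within the scatter).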

Compound 3, half-maximal inhibitory concentration: 20100 nM
Compound 3: the middle estimate sits 2.0-fold (0.30 log units) above what was measured; measured number inside the range.
By their numbers in this assay, from the lowest: compounds 2 and 3 (each within the scatter of the next); then compound 1.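

In this assay the amide-type nitrogen now carries a second group that differs from amino, and 1-carboxyethyl in place of amino gives a 2.4-fold lower number from compound 1 to compound 3 (0.38 log units; beyond the scatter); the lower number is therefore not peculiar to benzyl. With 1-carboxyethyl in place of benzyl there is a 1.2-fold higher number from compound 2 to compound 3 (0.07 log units; within the scatter), so these two groups cannot be told apart here. Nothing at hand accounts for the shift from amino.

Open, going by these compounds, is whether a plain methyl or a longer alkyl chain on this nitrogen would match compounds 2 and 3. Also open, on these data alone, is whether the carboxylic acid of compound 3 matters, which its methyl ester would test.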